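Another Aryl Swap on the Shared Core of Compound 1

The source may report more compounds than this note shows. Statements on the series, on what has been measured and on what is new or still open speak of the compounds shown alone.

Compound 1 `C/C(=C\CC/C(C)=C/CC[C@@H]1[C@@]2(C)CCC(=O)C(C)(C)[C@H]2CC[C@@]1(C)O)CC/C=C(\C)C(=O)OCc1cn(-c2ccc(F)c(Cl)c2)nn1` gives > 150000 nM in a functional assay on DU-145 cells (Homo sapiens) for antiproliferative activity, read by MTT assay, with a stated time of 48 h (a lower number here means a stronger inhibitor, a higher number a weaker inhibitor), a limit.
Compound 2 `C#CCOC(=O)/C(C)=C/CC/C(C)=C/CC/C(C)=C/CC[C@@H]1[C@@]2(C)CCC(=O)C(C)(C)[C@H]2CC[C@@]1(C)O` gives 46100 nM in this assay.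
Compound 3 `C/C(=C\CC/C(C)=C/CC[C@@H]1[C@@]2(C)CCC(=O)C(C)(C)[C@H]2CC[C@@]1(C)O)CC/C=C(\C)C(=O)OCc1cn(-c2cccc(F)c2)nn1` gives > 150000 nM in this assay, a limit.

Compound 1 stands at the limit of > 150000 nM in this assay, at which 2 of the 3 values shown sit, so no number is known for it. The change to compound 4 `C/C(=C\CC/C(C)=C/CC[C@@H]1[C@@]2(C)CCC(=O)C(C)(C)[C@H]2CC[C@@]1(C)O)CC/C=C(\C)C(=O)OCc1cn(-c2ccccc2Cl)nn1` is 2-chlorophenyl in place of 3-chloro-4-fluorophenyl on an aromatic nitrogen. The closest measured step, a step that the two limits leave unreadable from compound 1 to compound 3, swaps the aryl group on the same ring nitrogen, but both of its ends are limits and its size cannot be read. The other step, an at least 3.2-fold higher number from compound 2 to compound 3 (0.51 log units; beyond the scatter), shows that the aryl-bearing ring already carries the number upward toward the limit. Compound 4 is therefore expected to stay near that limit, a step of a number no higher from compound 1 to compound 4 (the limit leaves the size open), with an estimated 150000 nM in a range from 60000 nM to 400000 nM.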

Compound 4, half-maximal inhibitory concentration: > 150000 nM
Compound 4 gave a limit, no number (the forecaster's own chance of this, stated with the estimate: 70%); the middle value lies on the limit itself.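

Three different aryl groups on this ring nitrogen now end in the same place in this assay: the limit of > 150000 nM in this assay, at which 3 of the 4 values shown sit. A chlorine-only 2-chlorophenyl group therefore fares no differently at this limit from the two fluorinated aryl groups, and an at least 3.2-fold higher number from compound 2 to compound 4 (0.51 log units; beyond the scatter) extends to a third aryl group what was seen before. The steps among compound 1, compound 3 and compound 4 cannot be read, so these aryl groups cannot be ranked.

Going by these compounds, it stays open whether any aryl group here gives a number under the limit. A pyridyl ring or a benzyl group on this nitrogen could yet do so.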